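Swapping a Propyl for an Aryl Group on the Sulfonyl

The source may report more compounds than this note shows. Statements on the series, on what has been measured and on what is new or still open speak of the compounds shown alone.

Compound 1, `CCCS(=O)(=O)N1CCC2(CC1)OOC1(CCCCCC1)OO2`, was tested in a functional assay on Huh-7 cells (Homo sapiens) for cytotoxicity, read by MTT assay, with a stated time of 72 h; on this read-out higher numbers stand for lower toxicity in this test and lower numbers for higher toxicity in this test. In this assay compound 1 gives only a limit, > 100 ug/mL, so its true value is not known as a number. Compound 2, `O=S(=O)(Cc1ccccc1)N1CCC2(CC1)OOC1(CCCCC1)OO2`, is a related compound carrying a different group on the sulfonyl sulfur. In this assay compound 2 likewise gives only a limit, > 100 ug/mL. Among the measured compounds shown here, both measured values sit at the limit of > 100 ug/mL in this assay, at which 2 of the 2 values shown sit, so compound 1 stands in the same place as the only other compound measured. Compound 3, `O=S(=O)(c1ccc(Br)cc1F)N1CCC2(CC1)OOC1(CCCCCC1)OO2`, has not yet been measured. It differs from compound 1 in one place: 4-bromo-2-fluorophenyl in place of propyl on a sulfonyl sulfur. For the measured compounds named here, no step between measured compounds is known, so nothing shows how such a change moves toxicity in this assay. With both known values at the limit, the step from compound 1 to compound 3 is expected to be none beyond the scatter, a number no higher from compound 1 to compound 3 (the limit leaves the size open). Compound 3 is estimated at 100 ug/mL, within 50 ug/mL to 200 ug/mL.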

Compound 3, half-maximal cytotoxic concentration: > 100 ug/mL
Compound 3 was reported as a limit (the forecaster's own chance of this, stated with the estimate: 80%); the middle value sits exactly at the limit.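

Compound 3, like compound 1, is reported only as a limit, so no step between compound 1 and compound 3 can be read in this assay: the limit of > 100 ug/mL in this assay, at which 3 of the 3 values shown sit.

The compounds shown leave open whether 4-bromo-2-fluorophenyl in place of propyl on a sulfonyl sulfur changes toxicity at all.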